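The source may hold more compounds than are shown below. What is called first, only, known or untested is meant among the compounds shown, and "the series" means these compounds.

In a functional assay on the whole organism for activation, with Mus musculus as the target (on this read-out higher numbers stand for an effect only at larger amounts of compound and lower numbers for an effect already at smaller amounts), compound 3 `Nc1ncnc2c1nc(O)n2Cc1ccccc1` gives 30 mg/kg, the highest number among the three measured compounds. Compound 1 `Cc1nc(N)c2nc(O)n(Cc3ccccc3)c2n1` gives 3 mg/kg, and compound 2 `Nc1nc(O)nc2c1nc(O)n2Cc1ccccc1` gives 1 mg/kg. Both steps that lead to compound 3 make the number larger: a 10-fold higher number from compound 1 to compound 3 (1.00 log units; beyond the scatter) and a 30-fold higher number from compound 2 to compound 3 (1.48 log units; beyond the scatter). The step to compound 4 `CCCOc1nc(N)c2nc(O)n(Cc3ccccc3)c2n1` works at the same aromatic carbon: propoxy in place of hydrogen on an aromatic carbon. The two measured steps show that a methyl or a hydroxy on this carbon goes with a markedly lower number in this assay than hydrogen does, and propoxy is a further group placed there. Whether propoxy matches hydroxy or methyl cannot be told from two steps alone, so the expectation is anchored closer to the methyl case than to the hydroxy case. On that basis compound 4 is expected to give a lower number, a step of a 10-fold lower number from compound 3 to compound 4 (1.00 log units; beyond the scatter), beyond the scatter. Compound 4 is estimated in this assay at 3 mg/kg, with a range from 1 mg/kg to 10 mg/kg.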

Compound 4, minimum effective dose: 0.3 mg/kg
Estimate against measurement, compound 4: 10-fold (1.00 log units) above; the measured number lies below the stated range.
By their numbers in this assay, from the lowest: compound 4; then compound 2; then compound 1; then compound 3.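

In this assay propoxy on this carbon, between two ring nitrogen atoms, goes further than either smaller group: set against hydrogen it gives a 100-fold lower number from compound 3 to compound 4 (2.00 log units; beyond the scatter) and the lowest number of the four compounds, and set against methyl it gives a 10-fold lower number from compound 1 to compound 4 (1.00 log units; beyond the scatter) in the same direction. The hydroxy hydrogen is not needed for a low number either, as propyl in its place on the oxygen gives a 3.3-fold lower number from compound 2 to compound 4 (0.52 log units; beyond the scatter) and no loss. The position therefore takes a propoxy chain, and the numbers at this carbon fall from hydrogen through methyl and hydroxy to propoxy, with no compound shown going against that order.

Still open, on these data alone, is whether a longer chain such as butoxy or pentoxy lowers the number further, and whether propylamino or plain butyl at this carbon matches propoxy. Nothing at hand explains why these steps run as they do.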